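This account rests on a few compounds, and the source may have more. Where it says the series, first, only, none or still open, it means among the compounds named here.

Three closely related thiosemicarbazones have been tested in a functional assay on MCF7 cells (Homo sapiens) for cytotoxicity, read by MTT assay, with a stated time of 48 h; on this read-out lower numbers stand for stronger inhibition and higher numbers for weaker inhibition. Compound 1 `C/C(=N\NC(=S)Nc1ccc(Cl)cc1)c1ccccn1` gives 8.49 nM. Compound 2 `C/C(=N\NC(=S)Nc1ccc(I)cc1)c1ccccn1` carries iodo where compound 1 carries chloro; compound 2 gives 6.61 nM. Compound 3 `CC(=NNC(=S)Nc1ccc(I)cc1)c1ccccn1` has the same atoms and bonds as compound 2; compound 3 gives 6.6 nM.

Two single-point comparisons can be drawn. Between compound 2 and compound 1 the change is chloro in place of iodo on an aromatic carbon, and the step is a 1.3-fold higher number from compound 2 to compound 1 (0.11 log units; within the scatter). Between compound 2 and compound 3 the difference is the two compounds have the same atoms and bonds; at least one stereo element is drawn with a configuration in one of them and without one in the other: 1 of 1 stereo elements differ; a double bond is drawn E in compound 2 and without a configuration in compound 3; the step is a 1.0-fold lower number from compound 2 to compound 3 (0.00 log units; within the scatter), and the only thing that separates the two drawings is the fact that one of compounds 2 and 3 is drawn with a defined configuration and the other without, at the place where they differ. All three values sit within the usual spread of such measurements, so none of the three can be called more or less potent than another.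

Compound 4 `CC(=NNC(=S)Nc1ccc(Cl)cc1)c1ccccn1` has not yet been measured in this assay. It relates to compound 3 in the same way that compound 1 relates to compound 2: the change is chloro in place of iodo on an aromatic carbon, made at exactly the same place on the ring. The cores of compound 3 and compound 2 differ only in the drawn configuration of the double bond, as set out above.

The step from compound 3 to compound 4 is expected to be a 1.3-fold higher number from compound 3 to compound 4 (0.11 log units; within the scatter), resting on the measured step of a 1.3-fold higher number from compound 2 to compound 1 (0.11 log units; within the scatter) for the same change in compound 2 and compound 1. Compound 4 is therefore estimated to give 8.5 nM, with a likely range from 5 nM to 14 nM.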

Compound 4, half-maximal inhibitory concentration: 8.5 nM
Beside the measured number, compound 4's estimate shows no gap at the digits printed; the measured number falls inside the stated range.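

In this assay, putting chloro in place of iodo gives a 1.3-fold higher number from compound 3 to compound 4 (0.11 log units; within the scatter), and the same change on the other core gives a matching result: the same change on two cores in this assay, a 1.3-fold higher number (0.11 log units; within the scatter) from compound 2 to compound 1 and a 1.3-fold higher number (0.11 log units; within the scatter) from compound 3 to compound 4, 1.0-fold (0.00 log units) apart, within the scatter of two such steps. The other new step, a 1.0-fold higher number from compound 1 to compound 4 (0.00 log units; within the scatter), involves no change of group at all, only a change in how the structure is drawn: the fact that one of compounds 1 and 4 is drawn with a defined configuration and the other without, at the place where they differ. So the change carries over in the sense that it stays too small to read on both cores, but this is a weak test: the two cores have the same atoms and bonds, and neither step can show whether chloro and iodo truly differ in this assay, or whether this change would behave alike on a core that really differs.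

The compounds shown leave open what happens with a group other than chloro or iodo at this place on the ring, such as an amine or a carboxylic acid, where a step large enough to read might appear. They also leave open whether a compound drawn without a configuration at the double bond is the same material as its partner drawn with one, since the drawings alone cannot tell.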